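Swapping Fluoro for Trifluoromethyl on the Fused Ring

The source may report more compounds than this note shows. Statements on the series, on what has been measured and on what is new or still open speak of the compounds shown alone.

Of the compounds shown here, two have been measured in a functional assay on cells for positive allosteric modulation of metabotropic glutamate receptor 2 (Homo sapiens), read by fluorescence and calcium flux, with a stated time of 30 min; a higher number here means that more compound is needed for the effect, a lower number that less compound is needed. Compound 1 `Clc1ccc(-c2ccc(Cn3nnc4ccccc43)cc2)c(Cl)c1` gives 79 nM. Compound 2 `Fc1cc(Cl)ccc1-c1ccc(Cn2nnc3c(F)cccc32)cn1` gives 27 nM, the lower of the two numbers, and its gap to compound 1 lies beyond the usual scatter.

Compound 3 `Fc1cc(Cl)ccc1-c1ccc(Cn2nnc3c(C(F)(F)F)cccc32)cn1` differs from compound 2 in one place: trifluoromethyl in place of fluoro on an aromatic carbon. Among the compounds with values here, no measured pair shows this change, so the step it brings in this assay is expected to be small, in either direction, and likely within the scatter. The estimated step is a 1.1-fold higher number from compound 2 to compound 3 (0.05 log units; within the scatter). Compound 3 is estimated at 30 nM, with a range from 10 nM to 90 nM.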

Compound 3, half-maximal effective concentration: 13 nM
Compound 3: middle estimate off by 2.3-fold (0.36 log units), on the high side; the range from low to high includes it.
By their numbers in this assay, from the lowest: compound 3; then compound 2; then compound 1.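

On this aromatic carbon of the fused ring, trifluoromethyl in place of fluoro gives a 2.1-fold lower number from compound 2 to compound 3 (0.32 log units; beyond the scatter) in this assay. The position therefore accepts a group with more heavy atoms, and here the number falls rather than rises. Nothing measured here explains why the number falls.

This is a single pair on one core, so it cannot show whether the gain would carry over to other cores. From the compounds shown here alone, whether an amine, a nitrile or a longer chain on this carbon would lower the number further also stays open.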